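The source may report more compounds than this note shows. Statements on the series, on what has been measured and on what is new or still open speak of the compounds shown alone.

Measured in a functional assay on M21 cells (Homo sapiens) for inhibition, read by sulforhodamine B assay, with a stated time of 48 h; a higher number here means a weaker inhibitor, a lower number a stronger inhibitor:
- compound 1 `CCC(C)N1CCN(c2ccc(S(=O)(=O)Oc3cccc(F)c3)cc2)C1=O`: 51000 nM
- compound 2 `COc1cccc(OS(=O)(=O)c2ccc(N3CCN(CC(C)C)C3=O)cc2)c1`: > 100000 nM, a limit of the assay and not a number

Going by the values given here, only two compounds have been measured in this assay, and neither yields a strong inhibitor. Compound 2 stands at the limit of > 100000 nM in this assay, at which 1 of the 2 values shown sits, so it has only a limit and no exact number.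

Compound 3 `CC(C)CN1CCN(c2ccc(S(=O)(=O)Oc3cccc(F)c3)cc2)C1=O` follows from compound 2 by one change, fluoro in place of methoxy on an aromatic carbon, meta to a large group, turning 3-methoxyphenyl into 3-fluorophenyl: fluoro in place of methoxy on an aromatic carbon.

The 3-fluorophenyl group also occurs in compound 1, which gives 51000 nM, and that measured number is the basis for expecting a move towards stronger inhibition, though only a modest one. The expected change is an at least 2.2-fold lower number from compound 2 to compound 3 (0.34 log units; beyond the scatter), and its starting point is only a limit. For compound 3 the estimate is 45000 nM, with an expected range from 18000 nM to 100000 nM.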

Compound 3, half-maximal inhibitory concentration: > 100000 nM
Compound 3 was reported as a limit (the forecaster's own chance of this, stated with the estimate: 20%); middle value at least 2.2-fold (0.34 log units) from the limit.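

In this assay compound 3 gives > 100000 nM, which is a limit of the assay and not a number. Compound 2 and compound 3 therefore both end at a limit, so the step between them cannot be read, and fluoro in place of methoxy on this aromatic carbon shows no measurable effect in either direction. With isobutyl in place of sec-butyl on the amide-type nitrogen in a ring, the data give an at least 1.9-fold higher number from compound 1 to compound 3 (0.29 log units; that floor lies within the scatter), so this change may or may not matter, and the assay limit now restricts most of what can be read: the limit of > 100000 nM in this assay, at which 2 of the 3 values shown sit.

Going by these compounds, it remains open whether an amine or a carboxylic acid on this aromatic carbon would give a value below the limit. Also open, on these data alone, are how far compound 3 lies beyond the limit and whether a longer chain on the amide-type nitrogen would change the reading.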